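The source may hold more compounds than are shown below. What is called first, only, known or untested is meant among the compounds shown, and "the series" means these compounds.

Measured compounds:
- compound 1, `Cc1c(C(=O)N=[N+]=[N-])[n+]([O-])c2cc(Cl)ccc2[n+]1[O-]`: 84.2%
- compound 2, `COc1ccc2c(c1)[n+]([O-])c(C(=O)N=[N+]=[N-])c(C)[n+]2[O-]`: 11.3%
- compound 3, `Cc1c(NC(=O)OC(C)C)[n+]([O-])c2cc(Cl)ccc2[n+]1[O-]`: 96%

In a functional assay on Ehrlich cells (Mus musculus) for cytotoxicity, read by trypan blue exclusion, with a stated time of 2 h, tested at 25 ug/mL (on this read-out lower numbers stand for a stronger effect and higher numbers for a weaker effect at the one concentration tested), compound 3 gives 96%, the highest of the three numbers. Its nearest neighbour is compound 1, which gives 84.2%; the step of a number 11.8 percentage points higher from compound 1 to compound 3 (beyond the scatter) goes with the change described above. Far below both stands compound 2 with 11.3%.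

Compound 4, `COc1ccc2c(c1)[n+]([O-])c(NC(=O)OC(C)C)c(C)[n+]2[O-]`, has not yet been measured in this assay. Its change from compound 3 is methoxy in place of chloro on an aromatic carbon.

Going by the values given here, one measured step bears on it directly: a number 72.9 percentage points lower from compound 1 to compound 2 (beyond the scatter), the same exchange of groups on the same aromatic carbon of the shared core, there carried out beside the other substituent. That step was large and downward. Among the compounds with values here, no step shows how the exchange behaves beside the group that compound 3 carries, so the size is uncertain, but the direction is taken from the one comparison that exists. A large downward step is therefore expected, a number 66 percentage points lower from compound 3 to compound 4 (beyond the scatter), though perhaps not as large as the one seen before. For compound 4 the expected value in this assay is 30%, within a range from 10% to 65%.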

Compound 4, a percentage reported as activity, at one concentration (the size of the read-out at that concentration, not a potency): 82.3%
Compound 4: middle estimate off by 52.3 percentage points, on the low side; the whole stated range lies below it.
By their numbers in this assay, from the lowest: compound 2; then compounds 4 and 1 (each within the scatter of the next); then compound 3.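

In this assay, methoxy in place of chloro has no fixed effect on this aromatic carbon: in the compounds carrying the group of 7 heavy atoms, the exchange gives a number 13.7 percentage points lower from compound 3 to compound 4 (beyond the scatter). The size of the step therefore depends on which of the two groups the compound carries: the same change on two cores in this assay, a number 72.9 percentage points lower (beyond the scatter) from compound 1 to compound 2 and a number 13.7 percentage points lower (beyond the scatter) from compound 3 to compound 4, 59.2 percentage points apart, beyond the scatter of two such steps

Seen from the other side, the exchange of the two groups gives a number 71 percentage points higher from compound 2 to compound 4 (beyond the scatter), so it too depends on whether chloro or methoxy is present: the same change on two cores in this assay, a number 11.8 percentage points higher (beyond the scatter) from compound 1 to compound 3 and a number 71 percentage points higher (beyond the scatter) from compound 2 to compound 4, 59.2 percentage points apart, beyond the scatter of two such steps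

Going by these compounds, with only these four compounds, it remains open whether the low number of compound 2, 11.3%, is specific to methoxy or would also appear with another group on that aromatic carbon, such as ethoxy or an amine. On these data alone, it is equally open how a carboxylic acid or a longer chain would behave in place of the group of 5 heavy atoms.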